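The compounds below may be only part of what the source reports. "The series", "measured", "known", "first", "only" and "open" are said of these compounds alone.

Measured compounds:
compound 1 `CCn1c(-c2cnc(C)nc2)nc2c(O[C@H]3CCN(C(=O)C4CC4)C3)ncnc21`: 0.7 L/kg
compound 2 `CCn1c(-c2cnc(C)nc2)nc2c(N[C@H]3CCN(C(=O)C4CCOC4)C3)ncnc21`: 0.7 L/kg
compound 3 `CCn1c(-c2ccc(C(F)(F)F)nc2)nc2c(O[C@H]3CCN(C(=O)N4CC(OC)C4)C3)ncnc21`: 0.2 L/kg

Three compounds of this series have so far been run in an ADME assay (Rattus norvegicus, strain Wistar Han) for pharmacokinetics; a lower number here means that more of the compound stays in the plasma, a higher number that more of the compound sits outside the plasma. Compound 2 sits level with compound 1 at the digits shown, and the two together give the highest numbers of the three. Compound 3 returns a clearly lower number, and that gap to compound 2 lies beyond the usual scatter of repeated measurements; the other two differ by nothing that can be told apart from scatter.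

The next compound, compound 4 `CCn1c(-c2cnc(C)nc2)nc2c(N[C@H]3CCN(C(=O)[C@H]4C[C@@H](OC)C4)C3)ncnc21`, keeps the whole of compound 2 except for the group on the carbonyl carbon whose other neighbours are an amide-type nitrogen in a ring. There the oxolan-3-yl group leaves and a 3-methoxycyclobutyl group enters: 3-methoxycyclobutyl in place of oxolan-3-yl on a carbonyl carbon. The count of hydrogen-bond donors and acceptors stays the same, and no charge is gained or lost.

Within the data shown here, no measured pair in this set shows the effect of such a change, so the expectation for compound 4 rests on compound 2 alone, which gives 0.7 L/kg in this assay. The step from compound 2 to compound 4 is expected to be no change at the digits printed from compound 2 to compound 4 (within the scatter), that is, nothing beyond the scatter in either direction. Compound 4 is therefore estimated at 0.7 L/kg, within a range of 0.4 L/kg to 1.2 L/kg.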

Compound 4, volume of distribution: 1.5 L/kg
Beside the measured number, compound 4's estimate is 2.1-fold (0.33 log units) below it, and the stated range ends below it.
By their numbers in this assay, from the lowest: compound 3; then compounds 1 and 2 (each within the scatter of the next); then compound 4.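

In this assay, among these compounds, the group on the carbonyl carbon proves able to move the number, with a 2.1-fold higher number from compound 2 to compound 4 (0.33 log units; beyond the scatter); this modest step is the first change in a single place that can be read. Oxolan-3-yl and 3-methoxycyclobutyl match in their counts of hydrogen-bond donors and acceptors and neither carries a net charge, so a difference beyond the scatter arises here without any change in those counts. Nothing measured here accounts for the step.

The compounds shown leave open which part of the 3-methoxycyclobutyl group goes with the step: the four-membered carbon ring, the methoxy group or the two defined stereocentres, which a plain cyclobutyl, a 3-hydroxycyclobutyl or an oxetan-3-yl group on the same carbonyl carbon could begin to separate. They also leave open whether the same exchange would give a similar step on compound 1, or on compound 3 with its trifluoromethyl-bearing aromatic ring.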